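Swapping the aryl group on the shared core: working notes

The compounds below may be only part of what the source reports. "The series", "measured", "known", "first", "only" and "open" are said of these compounds alone.

Measured compounds, all in an in vitro assay on HEK385-7 cells for displacement of a labelled ligand from prostaglandin D2 receptor 2 (Homo sapiens); on this read-out lower numbers stand for stronger inhibition and higher numbers for weaker inhibition:
- compound 1, `O=C(O)Cc1sc(C(Cc2ccccc2)c2ccccc2)nc1-c1ccc(Cl)cc1`, gives 56 nM
- compound 2, `O=C(O)Cc1sc(C(c2ccccc2)c2ccccc2)nc1-c1cccc(F)c1`, gives 2.9 nM
- compound 3, `N#Cc1ccc(-c2nc(C(c3ccc(F)cc3)c3ccc(F)cc3)sc2CC(=O)O)cc1`, gives 150 nM

Compound 3 stands highest of the three numbers. Its nearest neighbour is compound 1, and that gap already lies beyond the usual scatter; compound 2 is furthest from it, a wide gap. Among the compounds with values here, the three compounds differ from one another in more than one place, so no single change can be read from their values, only that compound 2 sits at the low end and compound 3 at the high end.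

Compound 4, `Cc1cc(-c2nc(C(c3ccc(F)cc3)c3ccc(F)cc3)sc2CC(=O)O)ccn1`, has not been measured. It differs from compound 3 in one place: 2-methylpyridin-4-yl in place of 4-cyanophenyl on an aromatic carbon. The leaving group and the entering group each carry one hydrogen-bond acceptor and differ by one heavy atom, so the change is modest in size. Within the data shown here, there is no measured pair in this set that isolates a swap of this kind on this aromatic carbon, so the direction cannot be taken from the data.

The expectation for compound 4 in this assay is therefore a step of about a 1.5-fold lower number from compound 3 to compound 4 (0.18 log units; within the scatter), which is not beyond the scatter. Compound 4 is estimated at 100 nM, within 30 nM to 400 nM.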

Compound 4, half-maximal inhibitory concentration: 3.1 nM
Estimate against measurement, compound 4: 32-fold (1.51 log units) above; the measured number lies below the stated range.
By their numbers in this assay, from the lowest: compounds 2 and 4 (each within the scatter of the next); then compound 1; then compound 3.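

This position is far from indifferent to the aryl group. In this assay, within the data shown here, 2-methylpyridin-4-yl in place of 4-cyanophenyl on the aromatic carbon next to the ring nitrogen gives a 48-fold lower number from compound 3 to compound 4 (1.68 log units; beyond the scatter), the only single-place step and a large one. The size of the step does not follow from the counts: the leaving and entering groups have the same number of hydrogen-bond acceptors, neither has a donor, and they differ by one heavy atom, while nothing measured here accounts for the change in the read-out.

The swap changes several things at once, so a pyridin-4-yl without the methyl and a 4-methylphenyl on this carbon would be needed to separate the part played by the ring nitrogen from that of the methyl group and the loss of the nitrile. Among these compounds, the step is also read against only one large group on the shared core, the one carried by both compound 3 and compound 4, so whether the same swap holds with a different large group stays open.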